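One Hydroxy Added to Compound 3

The compounds below may be only part of what the source reports. "The series", "measured", "known", "first", "only" and "open" are said of these compounds alone.

Three compounds share a core and differ in the group on an aromatic nitrogen. In a functional assay on HeLa cells (Homo sapiens) for antiproliferative activity, read by MTT assay, with a stated time of 72 h (a higher number here means a weaker inhibitor, a lower number a stronger inhibitor), compound 1 `COc1cc(-c2nccn2C(C)C)cc(OC)c1OC` reaches only a limit, > 100000 nM. Compound 2 `COc1cc(-c2nccn2Cc2ccccc2)cc(OC)c1OC` also reaches only a limit, > 100000 nM. These two limits leave a step that the two limits leave unreadable from compound 1 to compound 2. Within the data shown here, compound 3 `COc1ccc(-n2ccnc2-c2cc(OC)c(OC)c(OC)c2)cc1` gives 1200 nM, the only actual number so far.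

Placing 4-methoxyphenyl in place of isopropyl gives an at least 83-fold lower number from compound 1 to compound 3 (1.92 log units; beyond the scatter). Placing it in place of benzyl gives an at least 83-fold lower number from compound 2 to compound 3 (1.92 log units; beyond the scatter). Both large steps involve the group that changes next.

Compound 4 `COc1ccc(-n2ccnc2-c2cc(OC)c(OC)c(OC)c2)cc1O` carries hydroxy in place of hydrogen on an aromatic carbon, ortho to a methoxy group: hydroxy in place of hydrogen on an aromatic carbon. Among the measured compounds shown here, no measured step adds a hydroxy, so the two large steps show only that this part of compound 3 can matter greatly, not what this smaller edit will do. A modest gain in this assay seems the likelier outcome, far smaller than an at least 83-fold lower number from compound 1 to compound 3 (1.92 log units; beyond the scatter), though a loss remains possible. The expected change is a 4.0-fold lower number from compound 3 to compound 4 (0.60 log units; beyond the scatter). The estimated value for compound 4 is 300 nM, with an expected range from 30 nM to 3000 nM.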

Compound 4, half-maximal inhibitory concentration: 100 nM
Compound 4: the middle estimate sits 3.0-fold (0.48 log units) above what was measured; the measured number falls inside the stated range.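

In this assay, the hydroxy is the first change shown on the 4-methoxyphenyl group itself, not a swap of the whole group on the aromatic nitrogen, and it gives a 12-fold lower number from compound 3 to compound 4 (1.08 log units; beyond the scatter). This place, an aromatic carbon ortho to a methoxy group and meta to a large group, therefore matters: adding just 1 heavy atom moves the number by a large step, while everything else in the molecule stays the same. The values shown include no measured property that bears on this gain, so they do not explain it.

The compounds shown leave open whether the gain needs the hydroxy itself, or whether an amine, a fluorine or a methyl group at the same carbon would give a similar result. As far as these compounds go, it also remains open whether a hydroxy on a different carbon of that ring would help, and whether replacing the neighbouring methoxy group with an ethoxy group would change the effect of the hydroxy.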